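The source may hold more compounds than are shown below. What is called first, only, known or untested is meant among the compounds shown, and "the series" means these compounds.

Working notes on three analogues sharing one core, read in a functional assay on HL-60 cells (Homo sapiens) for antiproliferative activity, read by MTT assay, with a stated time of 72 h; a higher number here means a weaker inhibitor, a lower number a stronger inhibitor. Compound 1 (`COc1cc(C(=O)c2sc3ccccc3c2-c2ccc(C)cc2)cc(OC)c1OC`) gives 1400 nM, compound 2 (`COc1ccccc1-c1c(C(=O)c2cc(OC)c(OC)c(OC)c2)sc2ccccc12`) gives 2900 nM, and compound 3 (`COc1cc(C(=O)c2sc3ccccc3c2Nc2ccccc2)cc(OC)c1OC`) gives 5200 nM. Compound 3 cannot be told apart from compound 2, since a 1.8-fold higher number from compound 2 to compound 3 (0.25 log units; within the scatter) stays within the scatter. It does separate from compound 1, with a 3.7-fold higher number from compound 1 to compound 3 (0.57 log units; beyond the scatter). The remaining step, a 2.1-fold higher number from compound 1 to compound 2 (0.32 log units; beyond the scatter), is also modest.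

Compound 4 (`COc1cc(C(=O)c2sc3ccccc3c2Nc2ccc(Cl)cc2)cc(OC)c1OC`) keeps the anilino group and differs from compound 3 in one place: chloro in place of hydrogen on an aromatic carbon, para to a large group. Among the compounds with values here, no measured step makes this swap, so the three steps above bear on it only indirectly, as each replaces a whole group. The closest guide is compound 1, a 4-methylphenyl analogue at 1400 nM, which hints at a small move toward a lower number in this assay. The estimate is a 1.5-fold lower number from compound 3 to compound 4 (0.17 log units; within the scatter), an expected step that may not leave the scatter. For compound 4 the estimated value is 3500 nM, with an expected range of 1300 nM to 9500 nM.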

Compound 4, half-maximal inhibitory concentration: 5400 nM
Estimate against measurement, compound 4: 1.5-fold (0.19 log units) below; the range from low to high includes it.
By their numbers in this assay, from the lowest: compound 1; then compounds 2, 3 and 4 (each within the scatter of the next).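

In this assay, within the data shown here, chloro in place of hydrogen, para to a large group, gives the first direct reading of a substituent on the anilino ring: a 1.0-fold higher number from compound 3 to compound 4 (0.02 log units; within the scatter), so this change leaves the number unresolved from that of the unsubstituted anilino compound. The other two steps keep the earlier picture, with a 1.9-fold higher number from compound 2 to compound 4 (0.27 log units; within the scatter) remaining unresolved and a 3.9-fold higher number from compound 1 to compound 4 (0.59 log units; beyond the scatter) keeping the 4-methylphenyl analogue apart, so chloro at this place does not close that gap. Nothing available bears on why the chloro step is so small.

From the compounds shown here alone, whether this flat reading is particular to chloro stays open, since a methoxy group, a carboxylic acid or a dimethylamino group at the same place could read differently. A single substituent also cannot show how far this ring tolerates change in general.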